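The source may hold more compounds than are shown below. What is called first, only, known or untested is meant among the compounds shown, and "the series" means these compounds.

compound 1 `CCCCCCC(CCO)n1cnc2c(NC)ncnc21`: > 50000 nM
compound 2 `CCCCCCC(CCO)n1cnc2c(N)ncnc21`: > 50000 nM

In a functional assay on SW480 cells (Homo sapiens) for antiproliferative activity, read by MTT assay, with a stated time of 48 h (a higher number here means a weaker inhibitor, a lower number a stronger inhibitor), compound 1 gives only a limit, > 50000 nM, and no number. Compound 2 also gives only a limit, > 50000 nM. The data so far consist of the limit of > 50000 nM in this assay, at which 2 of the 2 values shown sit. Within the data shown here, the only measured step is a step that the two limits leave unreadable from compound 1 to compound 2. That step lies at a nitrogen and not on the chain, and it supplies no size to carry forward.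

Compound 3 `CCCCCCCCCC(CCO)n1cnc2c(NC)ncnc21` differs from compound 1 by propyl in place of hydrogen on a saturated chain carbon, seven bonds along the chain from an aromatic nitrogen. Among the measured compounds shown here, no measured step covers a change on this chain, so the data fix neither the size nor the direction of the change in this assay. Compound 3 may well be reported as a limit again. Any number that does appear is expected on the stronger side of the limit of compound 1, > 50000 nM. The expected change is an at least 1.4-fold lower number from compound 1 to compound 3 (0.15 log units; that floor lies within the scatter), and it is a tentative expectation. Compound 3 is estimated at 35000 nM, with an expected range from 10000 nM to 50000 nM.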

Compound 3, half-maximal inhibitory concentration: 4450 nM
Estimate against measurement, compound 3: 7.9-fold (0.90 log units) above; measured number below the stated range.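

Propyl in place of hydrogen on a saturated chain carbon, seven bonds along the chain from an aromatic nitrogen, gives an at least 11-fold lower number from compound 1 to compound 3 (1.05 log units; beyond the scatter) in this assay. This chain position is therefore the first place in the series where a change yields a readable number, whereas the earlier change at the nitrogen yielded none. One end of the step is a limit, so its size is a floor and not a measured difference, and the other values remain at a single limit: the limit of > 50000 nM in this assay, at which 2 of the 3 values shown sit.

On these data alone, a single extension of the chain gives no trend, so it remains open whether a longer chain, a methyl or ethyl in place of the same hydrogen, or a chain ending in an amine or a carboxylic acid would move the number further, hold it or lose it. As far as these compounds go, the step from compound 1 to compound 2 cannot be read, so the role of the methyl on the nitrogen is also open, including whether hydrogen in its place would change the number on the longer chain of compound 3.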